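Extending the Amino-Acid Tail: From Compound 2 to Compound 3

The source may report more compounds than this note shows. Statements on the series, on what has been measured and on what is new or still open speak of the compounds shown alone.

Two measured compounds share a core and differ only in their amino-acid tail. Compound 1 `COC(=O)[C@@H](N)CC(=O)NCCOc1ccc(C2=[N+]([O-])C(C)(C)C(C)(C)N2O)cc1` gives 47800 nM in a functional assay on PC-12 cells (Rattus norvegicus) for inhibition, read by MTT assay; on this read-out lower numbers stand for an effect already at smaller amounts and higher numbers for an effect only at larger amounts of compound; compound 2 `CC1(C)N(O)C(c2ccc(OCCNC(=O)CC[C@H](N)C(=O)O)cc2)=[N+]([O-])C1(C)C` gives 49600 nM. Going by the values given here, the single change between them, 2-amino-2-carboxyethyl in place of amino(methoxycarbonyl)methyl, gave a 1.0-fold higher number from compound 1 to compound 2 (0.02 log units; within the scatter), so compound 2 stands within the scatter of compound 1 and the two cannot be ordered. Compound 3 `CC1(C)N(O)C(c2ccc(OCCNC(=O)CC[C@H](N)C(=O)N[C@H](CS)C(=O)NCC(=O)O)cc2)=[N+]([O-])C1(C)C` has not yet been measured. It differs from compound 2 by (1-((carboxymethyl)carbamoyl)-2-sulfanylethyl)amino in place of hydroxy on a carbonyl carbon. Among the compounds with values here, no measured step touches this carbonyl carbon; the only step available, from compound 1 to compound 2, shows that replacing the tail left the number unchanged. On that basis a step of a 1.0-fold higher number from compound 2 to compound 3 (0.02 log units; within the scatter) is expected, with nothing beyond the scatter. Compound 3 is therefore estimated at 52000 nM, with a range from 20000 nM to 135000 nM.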

Compound 3, half-maximal effective concentration: 47000 nM
Compound 3: the middle estimate sits 1.1-fold (0.04 log units) above what was measured; measured number inside the range.
By their numbers in this assay, from the lowest: compounds 3, 1 and 2 (each within the scatter of the next).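

On the carbonyl carbon, (1-((carboxymethyl)carbamoyl)-2-sulfanylethyl)amino took the place of hydroxy, so 11 heavy atoms entered where 1 left, and this assay showed a 1.1-fold lower number from compound 2 to compound 3 (0.02 log units; within the scatter) with no shift beyond the scatter. Going by these compounds alone, the earlier pair had changed the tail elsewhere, so this is the first sign that this carbonyl carbon accepts a much larger group, one carrying a sulfanyl group, without the read-out moving. No measurement shown explains this result.

Going by these compounds, whether a dimethylamino group or a longer peptide chain on this carbonyl carbon would move the number remains open. Also open, on these data alone, is whether a change to the shared core, rather than to the tail, would bring an effect at smaller amounts of compound.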